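This account rests on a few compounds, and the source may have more. Where it says the series, first, only, none or still open, it means among the compounds named here.

Measured in a functional assay on MCF7 cells (Homo sapiens) for antiproliferative activity, read by CCK-8 assay, with a stated time of 72 h; a higher number here means a weaker inhibitor of growth, a lower number a stronger inhibitor of growth:

compound 1 (`CCC1C(=O)N(C)c2cnc(-n3ccc4cc(C(=O)NC(C)C)ccc43)nc2N1c1ccn(C)n1`) gives 8420 nM
compound 2 (`CC[C@@H]1C(=O)N(C)c2cnc(Nc3ccc(S(=O)(=O)NC4CCCC4)cc3)nc2N1C1CCCC1`) gives 688 nM
compound 3 (`CC[C@@H]1C(=O)N(C)c2cnc(Nc3ccc(S(=O)(=O)NCCO)cc3)nc2N1C1CCCC1`) gives 344 nM

Compound 1 has the highest of these numbers, which makes it the weakest growth inhibitor of the three, and compound 2 and compound 3 both lie beyond the scatter from it. Compound 4 (`CCC1C(=O)N(C)c2cnc(-n3ccc4cc(C(=O)NC5CCCC5)ccc43)nc2N1c1ccn(C)n1`) keeps the core of compound 1 and carries cyclopentyl in place of isopropyl on an amide-type nitrogen. Within the data shown here, no measured step shows this exact change. The closest evidence comes from a different pair, where 2-hydroxyethyl replaces cyclopentyl on a sulfonamide nitrogen (a 2.0-fold lower number from compound 2 to compound 3 (0.30 log units; within the scatter)). That step stays within the scatter and sits on another kind of nitrogen, so it offers only weak guidance. A step beyond the scatter in this assay is therefore not expected, and no firm direction can be given. Compound 4 is estimated at 6500 nM (expected range 2200 nM to 20000 nM). The expected change is small (a 1.3-fold lower number from compound 1 to compound 4 (0.11 log units; within the scatter)).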

Compound 4, concentration for 50% growth inhibition: "not active" (no number reported)
The entry for compound 4 holds no number; no gap can be computed for the estimate.
By their numbers in this assay, from the lowest: compounds 3 and 2 (each within the scatter of the next); then compound 1.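

Among these compounds, compound 4 is reported as "not active" with no number, so no step from compound 1 to compound 4 can be read. On these data alone, how far cyclopentyl in place of isopropyl on the amide-type nitrogen shifts growth inhibition stays open. No evidence shown here bears on this result.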